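Methylation of the Aromatic Nitrogen in a Thienopyrimidine Series

This account rests on a few compounds, and the source may have more. Where it says the series, first, only, none or still open, it means among the compounds named here.

Of the compounds shown here, three have been measured in a functional assay on A549 cells (Homo sapiens) for inhibition, read by MTT assay, with a stated time of 72 h, tested at 20 uM; on this read-out lower numbers stand for less inhibition and higher numbers for more inhibition at the one concentration tested (going by the name of the read-out). Compound 1, `CN(c1ccc(Oc2ncnc3ccsc23)cc1)c1nccc(N2CCCC2)n1`, gives 63.9% in this assay. Compound 2, `c1ccc2c(c1)CCN2c1ccnc(Nc2ccc(Oc3ncnc4sccc34)cc2)n1`, gives 2.81%, the lowest of the three numbers. Compound 3, `c1cc(N2CCCC2)nc(Nc2ccc(Oc3ncnc4ccsc34)cc2)n1`, gives 23.2%.

Compounds 3 and 1 differ in a single place, (methyl in place of hydrogen on a nitrogen on an aromatic ring), and this change produced a number 40.7 percentage points higher from compound 3 to compound 1 (beyond the scatter). Among the compounds with values here, compound 2 is separated from compound 3 by more than one change; the difference between the two cores is not broken down here, and the two values show only that compound 2 sits well under compound 3.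

Compound 4, `CN(c1ccc(Oc2ncnc3sccc23)cc1)c1nccc(N2CCc3ccccc32)n1`, has not yet been measured. It stands to compound 2 as compound 1 stands to compound 3: the change is methyl in place of hydrogen on a nitrogen on an aromatic ring, the same change at the same kind of place, on a nitrogen on an aromatic ring whose other neighbours are aromatic carbon and aromatic carbon.

The expectation for compound 4 rests on one earlier instance of this change, which moved the read-out upward because of a number 40.7 percentage points higher from compound 3 to compound 1 (beyond the scatter). Since compound 2 starts from a far lower point and carries a different core, the same step is not taken for granted, and the expected step is a number 27.2 percentage points higher from compound 2 to compound 4 (beyond the scatter). Compound 4 is therefore estimated at 30%, with the likely range spanning from 5% to 60%.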

Compound 4, a percentage reported as inhibition, at one concentration (the size of the read-out at that concentration, not a potency): 29.4%
Beside the measured number, compound 4's estimate is 0.6 percentage points above it; the measured number falls inside the stated range.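

In this assay, methyl in place of hydrogen on a nitrogen on an aromatic ring gave a number 26.6 percentage points higher from compound 2 to compound 4 (beyond the scatter), so the change raised the read-out on this second core as well. The direction of the step therefore carried over from one core to the other, but its size did not stay the same: the same change on two cores in this assay, a number 40.7 percentage points higher (beyond the scatter) from compound 3 to compound 1 and a number 26.6 percentage points higher (beyond the scatter) from compound 2 to compound 4, 14.1 percentage points apart, beyond the scatter of two such steps. Within the data shown here, these two instances show only that the step on one core cannot be transferred to the other as a fixed amount; they do not show what in the cores sets the size of the step, or whether the upward direction would hold on any further core.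

The compounds shown leave open how an ethyl group, a longer chain or a carboxylic acid in place of the methyl on that nitrogen would read in this assay, since methyl is the only group shown there. They also leave open whether the two steps would keep their direction and size at other concentrations or on other cells, as every number here comes from a single concentration on a single cell line and none of them is a potency.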